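The compounds below may be only part of what the source reports. "The series", "measured", "known", "first", "only" and "open" are said of these compounds alone.

Working notes on the series, where the compounds share one core and differ in the aryl group on an aromatic nitrogen. In a functional assay on A549 cells (Homo sapiens) for inhibition, read by MTT assay, with a stated time of 24 h (on this read-out higher numbers stand for weaker inhibition and lower numbers for stronger inhibition), compound 1 `CC1(C)[C@H]2CC[C@]1(C)N(Cc1cn(-c3cccc(F)c3)nn1)C(=O)C2` gives 180 nM, compound 2 `CC1(C)[C@H]2CC[C@]1(C)N(Cc1cn(-c3ccccc3F)nn1)C(=O)C2` gives 240 nM and compound 3 `CC1(C)[C@H]2CC[C@]1(C)N(Cc1cn(-c3ccccc3Cl)nn1)C(=O)C2` gives 70 nM. Compound 3 has the lowest number of the three, and its gaps to both others lie beyond the scatter.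

Compound 4 `CC1(C)[C@H]2CC[C@]1(C)N(Cc1cn(-c3cccc(Cl)c3)nn1)C(=O)C2` has not yet been measured. The change is 3-chlorophenyl in place of 2-chlorophenyl on an aromatic nitrogen.

Going by the values given here, two measured steps bear on this. The matching change among the fluoro compounds is a 1.3-fold higher number from compound 1 to compound 2 (0.12 log units; within the scatter), and it runs from 3-fluorophenyl to 2-fluorophenyl. Chloro in place of fluoro gives a 3.4-fold lower number from compound 2 to compound 3 (0.54 log units; beyond the scatter). Among the compounds with values here, the fluoro pair is the only direct precedent, and it suggests that the change in group placement alone moves the number little. A single pair cannot show whether the chloro compounds behave alike, so the range stays wide and reaches the value of compound 1 on the upper side.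

The expected result in this assay is no step beyond the scatter, and the estimated step is a 1.1-fold higher number from compound 3 to compound 4 (0.03 log units; within the scatter). For compound 4 the estimate is 75 nM, with an expected range of 30 nM to 180 nM.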

Compound 4, half-maximal inhibitory concentration: 60 nM
Compound 4: the middle estimate sits 1.3-fold (0.10 log units) above what was measured, and the stated range covers the measured number.
By their numbers in this assay, from the lowest: compounds 4 and 3 (each within the scatter of the next); then compounds 1 and 2 (each within the scatter of the next).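

In this assay, going by these compounds alone, 3-chlorophenyl in place of 2-chlorophenyl gives a 1.2-fold lower number from compound 3 to compound 4 (0.07 log units; within the scatter), so the placement step now stays within the scatter for chloro as well as for fluoro, where the earlier compounds offered only the fluoro pair. Across the four compounds the halogen, rather than its placement, separates the numbers: chloro in place of fluoro gives a 3.0-fold lower number from compound 1 to compound 4 (0.48 log units; beyond the scatter), and 3-chlorophenyl in place of 2-fluorophenyl, which changes both halogen and placement, gives a 4.0-fold lower number from compound 2 to compound 4 (0.60 log units; beyond the scatter). The chloro-for-fluoro step, previously seen only with the 2-substituted aryl group, now also holds with the 3-substituted one, and the two steps agree: the same change on two cores in this assay, a 3.4-fold lower number (0.54 log units; beyond the scatter) from compound 2 to compound 3 and a 3.0-fold lower number (0.48 log units; beyond the scatter) from compound 1 to compound 4, 1.1-fold (0.06 log units) apart, within the scatter of two such steps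

The compounds shown leave open whether this separation extends to a bromo, methyl or trifluoromethyl group on the phenyl ring, and how an unsubstituted phenyl compares with the halogenated compounds. As far as these compounds go, it also remains open whether an amine or a carboxylic acid on the aryl group would keep the number near that of the chloro compounds.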